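The source may report more compounds than this note shows. Statements on the series, on what has been measured and on what is new or still open speak of the compounds shown alone.

Compound 2, with the structure `Nc1nc(N/N=C/c2ccc3ncccc3c2)nc2c1ncn2[C@@H]1O[C@H](CO)[C@@H](O)[C@H]1O`, carries a quinolin-6-yl group on the hydrazone carbon of the shared nucleoside core. In an assay on CHO-K1 cells for displacement of a labelled ligand from adenosine receptor A1 (Homo sapiens), read by scintillation counting, with a stated time of 60 min (on this read-out higher numbers stand for weaker inhibition and lower numbers for stronger inhibition), compound 2 gives 9.8 nM, the lowest of the two numbers in this set. Compound 1, with the structure `CC(/C=N/Nc1nc(N)c2ncn([C@@H]3O[C@H](CO)[C@@H](O)[C@H]3O)c2n1)Cc1ccc(C(C)C)cc1`, bears a branched aliphatic chain in the same position, and in this assay compound 1 gives 9500 nM, a value far beyond the scatter from that of compound 2. Compound 3, with the structure `COc1cc(/C=N/Nc2nc(N)c3ncn([C@@H]4O[C@H](CO)[C@@H](O)[C@H]4O)c3n2)cc(OC)c1OC`, carries a trimethoxyphenyl group; in this assay compound 3 gives > 10000 nM, which is a limit of the assay rather than a number (the limit of > 10000 nM in this assay, at which 1 of the 3 values shown sits).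

Compound 4, with the structure `Nc1nc(N/N=C/c2ccc(N3CCCC3)cc2)nc2c1ncn2[C@@H]1O[C@H](CO)[C@@H](O)[C@H]1O`, has not yet been measured. It differs from compound 2 in one place: 4-(pyrrolidin-1-yl)phenyl in place of quinolin-6-yl on a carbon with a double bond to nitrogen. The two measured aromatic hydrazones, compound 2 and compound 3, show that aromatic groups at this position can give either the lowest number or only a limit, so the outcome is not fixed by the aromatic character alone. Compound 4 keeps a six-membered aromatic ring of carbon only directly on the hydrazone carbon, and a modest loss relative to compound 2 is expected, with the step of a 6.1-fold higher number from compound 2 to compound 4 (0.79 log units; beyond the scatter) estimated as beyond the scatter. For compound 4 the expected value in this assay is 60 nM, within a range from 10 nM to 400 nM.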

Compound 4, inhibition constant: 5.1 nM
Compound 4: the middle estimate sits 12-fold (1.07 log units) above what was measured, outside the stated range (below it).
By their numbers in this assay, from the lowest: compounds 4 and 2 (each within the scatter of the next); then compound 1. At a limit, above all of these: compound 3.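

In this assay, putting 4-(pyrrolidin-1-yl)phenyl in place of quinolin-6-yl on a carbon with a double bond to nitrogen gives a 1.9-fold lower number from compound 2 to compound 4 (0.28 log units; within the scatter), so this assay does not tell the two groups apart. The earlier compounds shown here showed a low number at this position only with the quinolin-6-yl group, and the new result shows that this group, with its six-membered aromatic ring with 1 hetero atom, is not required for one: a six-membered aromatic ring of carbon only, carrying a five-membered non-aromatic ring, serves as well. That carbon-only ring does not settle the outcome by itself, since compound 3 also has such a ring on this carbon and its value is a limit and not a number: the limit of > 10000 nM in this assay, at which 1 of the 4 values shown sits.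

The compounds shown leave open how much of the result depends on the pyrrolidine ring itself, as opposed to the phenyl ring that carries it. A dimethylamino group, a piperidine or a morpholine in the same place on the phenyl ring would address this, and what lies behind the closeness of compound 2 and compound 4 also stays open.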